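A Smaller Amide Substituent in a Weakly Cytotoxic Set

The compounds below may be only part of what the source reports. "The series", "measured", "known", "first", "only" and "open" are said of these compounds alone.

In a functional assay on MDA-MB-435 cells (Homo sapiens) for cytotoxicity, read by MTT assay, with a stated time of 72 h (a lower number here means a stronger inhibitor, a higher number a weaker inhibitor), compound 1 (`C[C@H](NC(=O)c1nc(Br)c2cccnc2c1N[C@H]1CC[C@H](N)CC1)c1ccc(F)cc1`) gives > 10000 nM as its result, and that is a limit, not a number. Compound 2 (`CNc1c(C(=O)NCc2ccc(F)cc2)nc(Br)c2cccnc12`) gives > 20000 nM as its result, again only a limit. Going by the values given here, compound 3 (`O=CNCCCCCCNc1nc(C(=O)NCc2ccc(F)cc2)c(O)c2ncccc12`) gives 16000 nM as its result, the one true number among the three. Compound 1 therefore stands at the limit of > 10000 nM in this assay, at which 1 of the 3 values shown sits, and no exact place can be given for it.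

Compound 4 (`N[C@H]1CC[C@H](Nc2c(C(=O)Nc3ccccc3)nc(Br)c3cccnc23)CC1`) has not yet been measured. It carries phenyl in place of 1-(4-fluorophenyl)ethyl on an amide-type nitrogen and otherwise matches compound 1. Among the compounds with values here, no measured pair shows this change, so its effect in this assay cannot be read directly, and no step beyond the usual scatter is expected, in either direction. That expectation rests on compound 1 and its limit of > 10000 nM as the starting point. Within the data shown here, it also draws on compound 3 with its reading of 16000 nM as the only number available. The estimated move is a step that the limit leaves unreadable from compound 1 to compound 4 and it remains uncertain, since the starting point is only a limit. Compound 4 is expected to read about 14000 nM with an estimated range from 5000 nM to 40000 nM as its likely span.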

Compound 4, half-maximal inhibitory concentration: 1000 nM
Compound 4: the middle estimate sits 14-fold (1.15 log units) above what was measured, outside the stated range (below it).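

In this assay, going by these compounds alone, phenyl in place of 1-(4-fluorophenyl)ethyl on an amide-type nitrogen gives an at least 10-fold lower number from compound 1 to compound 4 (1.00 log units; beyond the scatter), the first readable step in the set, and it shows that the result at this position depends on the group the amide nitrogen carries. The group that leaves has 9 heavy atoms and 1 defined stereocentre, the group that enters has 6 heavy atoms and none, and both hold one six-membered aromatic ring of carbon only, so the ring type stays the same while the rest of the group goes. Compound 1 gives > 10000 nM in this assay, which is a limit, and the true size of the step therefore stays unfixed.

Nothing measured here bears on why the number falls with this change. On these data alone, whether a 4-fluorophenyl or a 1-phenylethyl group on the same amide-type nitrogen would read like compound 4 or like compound 1 stays open, and with it the question of which part of the departing group matters.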